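The source may hold more compounds than are shown below. What is called first, only, known or untested is meant among the compounds shown, and "the series" means these compounds.

Working notes on the series.

The parent, compound 1 `CN1CCc2nc(C#Cc3ccccc3)sc2C1`, carries a methyl on the ring amine and in an assay on HEK293 cells for positive allosteric modulation of metabotropic glutamate receptor 5 (Homo sapiens), read by FLIPR, with a stated time of 1 h (on this read-out lower numbers stand for an effect already at smaller amounts and higher numbers for an effect only at larger amounts of compound), gives 34 nM. Compound 2 `CCC(=O)N1CCc2nc(C#Cc3ccccc3)sc2C1` replaces that methyl with a propanoyl. For compound 2 in this assay only a limit is recorded, > 10000 nM, a limit of the method (the limit of > 10000 nM in this assay, at which 1 of the 2 values shown sits). Going by the values given here, the measured step of an at least 290-fold higher number from compound 1 to compound 2 (2.46 log units; beyond the scatter) is therefore the one relevant change: putting an acyl group on the ring nitrogen removes measurable activity.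

Compound 3 `O=C(C1CC1)N1CCc2nc(C#Cc3ccccc3)sc2C1` differs from compound 2 only in the acyl chain: cyclopropyl in place of ethyl on a carbonyl carbon. Among the compounds with values here, the amide on the ring nitrogen, the feature that carried the step of an at least 290-fold higher number from compound 1 to compound 2 (2.46 log units; beyond the scatter), is kept, and no measured step bears on exchanging ethyl for cyclopropyl at that carbonyl. Compound 3 is therefore expected to stay at or near the limit, and its this assay value is estimated at 15000 nM, within 3000 nM to 100000 nM. The step this estimate implies, a step that the limit leaves unreadable from compound 2 to compound 3, is expected to be none beyond the scatter.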

Compound 3, half-maximal effective concentration: > 10000 nM
Compound 3 ended at the assay's limit (the forecaster's own chance of this, stated with the estimate: 85%); the middle value does not contradict the limit.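

Cyclopropylcarbonyl in place of methyl on the amine nitrogen in the ring gives an at least 290-fold higher number from compound 1 to compound 3 (2.46 log units; beyond the scatter), so in this assay the loss seen with propanoyl is also seen with a second acyl group, one that carries a three-membered ring. The step from compound 2 to compound 3 cannot be read, and neither of the two can be ranked against the other, so nothing can be said about ethyl and cyclopropyl on the carbonyl carbon. Both acyl compounds end at the same limit of the method: the limit of > 10000 nM in this assay, at which 2 of the 3 values shown sit.

As far as these compounds go, whether the loss goes with the carbonyl itself or with the larger group on the ring nitrogen stays open. A plain ethyl or benzyl on that nitrogen would separate the two readings, and an acetyl would show whether any acyl group, however short, keeps a readable value.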